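The source may hold more compounds than are shown below. What is called first, only, known or untested is meant among the compounds shown, and "the series" means these compounds.

Measured so far in an assay on HEK293 cells for inhibition of acid ceramidase (Homo sapiens), read by fluorescence, with stated times of 10 min and 3 h; a lower number here means a stronger inhibitor, a higher number a weaker inhibitor:
Compound 1 `O=C(NCCCCc1ccccc1)n1c(=O)oc2cc(C3CCOCC3)ccc21`: 68 nM
Compound 2 `O=C(NCCCCc1ccccc1)n1c2c(oc1=O)CNCC2`: 340 nM
Compound 3 `CCOCCNC(=O)n1c(=O)oc2cc(-c3ccc(F)cc3)ccc21`: 2300 nM

Compound 1 stands at the lowest number of the three in this assay. Compound 2 is the nearest, at a higher number that lies beyond the scatter, and compound 3 sits furthest, at a still higher number, also beyond the scatter. For the measured compounds named here, all three differ from compound 1 in more than one place, so no single step between measured compounds is available to lean on.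

Compound 4 `CN1CCN(c2ccc3c(c2)oc(=O)n3C(=O)NCCCCc2ccccc2)CC1=O` has not yet been measured. It differs from compound 1 in one place: 4-methyl-3-oxopiperazin-1-yl in place of oxan-4-yl on an aromatic carbon. The shared core of compound 1 and the four-carbon chain ending in phenyl are kept.

Nothing among the three measured compounds isolates a change of this kind on that aromatic carbon, so the direction is uncertain. A small step is expected, most likely toward a somewhat higher number, and possibly within the scatter: the step expected from compound 1 to compound 4 is a 1.8-fold higher number from compound 1 to compound 4 (0.25 log units; within the scatter). Compound 4 is therefore estimated at 120 nM, with a range of 45 nM to 350 nM in this assay.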

Compound 4, half-maximal inhibitory concentration: 92 nM
Estimate against measurement, compound 4: 1.3-fold (0.12 log units) above, within the range that was stated.
By their numbers in this assay, from the lowest: compounds 1 and 4 (each within the scatter of the next); then compound 2; then compound 3.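

In this assay, 4-methyl-3-oxopiperazin-1-yl in place of oxan-4-yl on the aromatic carbon, meta to a fused ring and para to a fused ring, gives a 1.4-fold higher number from compound 1 to compound 4 (0.13 log units; within the scatter). For the compounds shown here, this is the first reading of a single change at this position, and it shows that compound 1 and compound 4 cannot be told apart in this assay, although the entering ring has 2 hetero atoms, 8 heavy atoms and 2 hydrogen-bond acceptors against 1 hetero atom, 6 heavy atoms and 1 hydrogen-bond acceptor in the ring that leaves. No measurement bears on why these two groups read alike.

Only non-aromatic six-membered rings have been compared at this carbon with the four-carbon chain ending in phenyl kept. Open, from the compounds shown here alone, is how a piperidine with a free ring amine, a carboxylic acid or a simple methoxy group would read there.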